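The source may report more compounds than this note shows. Statements on the series, on what has been measured and on what is new or still open speak of the compounds shown alone.

In a physicochemical assay for pharmacokinetics (on this read-out higher numbers stand for a longer-lived compound and lower numbers for a shorter-lived compound), compound 1 `O=C(NCc1ccccc1Cl)N1C(=O)c2ccccc2S1(=O)=O` gives > 166 h, which is a limit and not a number. Compound 2 `Cc1ccccc1CNC(=O)N1C(=O)c2ccccc2S1(=O)=O` gives > 166 h, which is also a limit, so compound 2 has no exact position on the scale. Among the measured compounds shown here, the whole series so far amounts to the limit of > 166 h in this assay, at which 2 of the 2 values shown sit.

Compound 3 `O=C(NCc1ccccc1C(F)(F)F)N1C(=O)c2ccccc2S1(=O)=O` differs from compound 2 by one change: trifluoromethyl in place of methyl on an aromatic carbon. Trifluoromethyl replaces methyl on an aromatic carbon, ortho to a large group. For the measured compounds named here, the only measured step that bears on this is a step that the two limits leave unreadable from compound 1 to compound 2. It is also a swap of one group on an aromatic carbon, but it offers no size to carry over.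

No step beyond the scatter is therefore expected in this assay, in either direction, and another limit is the likeliest reading. The expected step is a step that the limit leaves unreadable from compound 2 to compound 3. For compound 3 the estimated half-life is 200 h, with an expected range from 120 h to 330 h.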

Compound 3, half-life: > 166 h
Compound 3 ended at the assay's limit; the forecaster's own chance of this, stated with the estimate: 85%; the middle value is on the limit's open side.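

In this assay compound 3 gives > 166 h, which is a limit and not a number. Among the compounds shown here, no step among compound 1, compound 2 and compound 3 can be read. The true half-lives of all three compounds remain open, and so does whether chloro, methyl and trifluoromethyl differ at all in this respect: the limit of > 166 h in this assay, at which 3 of the 3 values shown sit.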